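This account rests on a few compounds, and the source may have more. Where it says the series, first, only, none or still open, it means among the compounds named here.

Working notes on the series. Compound 1 `Cn1nc(O)c(C(=O)Nc2cc(C(F)(F)F)cc(C(F)(F)F)c2)n1`, compound 2 `O=C(Nc1cccc(C(F)(F)F)c1)c1nsnc1O` and compound 3 `Cn1nnc(O)c1C(=O)Nc1cc(C(F)(F)F)cc(C(F)(F)F)c1` share an amide that joins a hydroxylated five-membered heteroaromatic ring to an aniline carrying one or two trifluoromethyl groups. In an assay on isolated protein for inhibition of mitogen-activated protein kinase kinase kinase 14 (Homo sapiens), read by ADP-Glo, with a stated time of 60 min, in the presence of a further agent that is not named here (a higher number here means a weaker inhibitor, a lower number a stronger inhibitor), compound 1 gives > 100000 nM, which is a limit of the assay and not a number. In this assay compound 2 gives > 100000 nM, again a limit. In this assay compound 3 gives > 100000 nM, also a limit. Compound 3 thus stands only at a limit, and the two further values shown are limits as well. Going by the values given here, the single step between measured compounds, a step that the two limits leave unreadable from compound 1 to compound 3, cannot be read in size because both ends sit at the limit of > 100000 nM in this assay, at which 3 of the 3 values shown sit.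

Compound 4 `Cc1c(C(=O)Nc2cc(C(F)(F)F)cc(C(F)(F)F)c2)c(O)nn1C` has not been measured in this assay. It differs from compound 3 by 3-hydroxy-1,5-dimethyl-1H-pyrazol-4-yl in place of 4-hydroxy-1-methyl-1H-1,2,3-triazol-5-yl on a carbonyl carbon. Among the compounds with values here, no measured step bears on this change with a readable size, and all three measured compounds sit at the limit of > 100000 nM in this assay, at which 3 of the 3 values shown sit, so the expectation for compound 4 rests on weak inhibition across the whole series. The expected step is a step that the limit leaves unreadable from compound 3 to compound 4, which is uncertain because compound 3 itself shows only (the limit of > 100000 nM in this assay, at which 3 of the 3 values shown sit). For compound 4 the estimated value in this assay is 200000 nM, with a range from 30000 nM to 1000000 nM.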

Compound 4, half-maximal inhibitory concentration: > 100000 nM
Compound 4: no number, only a limit; the forecaster's own chance of this, stated with the estimate: 75%; the middle value lies beyond the limit too.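

Compound 4 also gives only a limit in this assay, so neither its step from compound 3 nor its step from compound 1 can be read in size: the limit of > 100000 nM in this assay, at which 4 of the 4 values shown sit.

The compounds shown leave open which change to the hydroxylated ring or the aniline, if any, would give a readable number in this assay.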